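A few compounds are considered here, and "the series" means these few. Any claim that something is new, unique, unknown or untested is made for them only; others in the source may bear on it.

Three compounds share one core and differ in the aryl group on the ring nitrogen. Going by the values given here, in a functional assay on HL-60 cells (Homo sapiens) for inhibition, read by MTT assay, with a stated time of 72 h (a lower number here means a stronger inhibitor, a higher number a weaker inhibitor), compound 1 (`Cc1nc(-c2ccccc2)c(C(=O)N2CCN(c3cccc(Cl)c3Cl)CC2)o1`) gives 133 nM, the only number in the set. Compound 2 (`C=C(C)c1ccc(N2CCN(C(=O)c3oc(C)nc3-c3ccccc3)CC2)cc1`) is recorded as "not active" (no number reported). Compound 3 (`CC(=O)c1ccc(N2CCN(C(=O)c3oc(C)nc3-c3ccccc3)CC2)cc1`) is recorded as "not active" (no number reported), so it has no single number and shares that standing with compound 2.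

The unmeasured compound 4 (`Cc1nc(-c2ccccc2)c(C(=O)N2CCN(c3ccccc3Cl)CC2)o1`) carries 2-chlorophenyl in place of 4-acetylphenyl on an amine nitrogen in a ring. Its aryl group bears chlorine, as does that of compound 1 with 133 nM, whereas neither compound without chlorine gave a number. A step toward stronger inhibition is therefore expected in this assay, from no reported activity to a measurable value, although its size cannot be stated without a number for compound 3. With one chlorine rather than two, some loss against compound 1 is expected, and a result of no activity remains possible. For compound 4, the half-maximal inhibitory concentration is estimated at 300 nM, within an expected range of 80 nM to 1500 nM.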

Compound 4, half-maximal inhibitory concentration: 124 nM
Beside the measured number, compound 4's estimate is 2.4-fold (0.38 log units) above it, within the range that was stated.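

Exchanging one chloro group for hydrogen gives a 1.1-fold lower number from compound 1 to compound 4 (0.03 log units; within the scatter) in this assay, so the second chlorine of compound 1 is not needed for a value of this order. Compound 4, with 2-chlorophenyl on the amine nitrogen in the ring, has a number, whereas compound 2 and compound 3 are recorded as not active; the steps to compound 4 from these two cannot be read, but the contrast shows that the group at this position can decide between a measurable result and none. No measurement shown here accounts for this contrast.

Left open is whether an unsubstituted phenyl group would also give a number, or whether chlorine is required. On these data alone, it is also open whether methoxy or fluoro could take the place of the remaining chlorine.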